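The source may hold more compounds than are shown below. What is called first, only, known or untested is meant among the compounds shown, and "the series" means these compounds.

Of the compounds shown here, three have been tested in a functional assay on MCF7 cells (Homo sapiens) for antiproliferative activity, read by MTT assay, with a stated time of 72 h; a lower number here means a stronger inhibitor, a higher number a weaker inhibitor. Compound 1 `O=C(N/N=C/c1ccccc1)Nc1ccc(Oc2ccnc3[nH]ccc23)c(F)c1` gives 2380 nM. Compound 3 `O=C(N/N=C/c1ccccc1)Nc1ccc(Oc2ccnc3[nH]ccc23)cc1` differs from compound 1 by hydrogen in place of fluoro on an aromatic carbon, and in this assay compound 3 gives 1510 nM, a step of a 1.6-fold lower number from compound 1 to compound 3 (0.20 log units; within the scatter). Compound 2 `COc1ccc(/C=N/NC(=O)Nc2ccc(Oc3ccnc4[nH]ccc34)c(F)c2)c(OC)c1OC` carries a different core from compound 1; the difference between the two cores is not broken down here. In this assay compound 2 gives 134 nM, which sets it well apart from both compound 1 and compound 3.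

Compound 4 `COc1ccc(/C=N/NC(=O)Nc2ccc(Oc3ccnc4[nH]ccc34)cc2)c(OC)c1OC` has not yet been measured. It differs from compound 2 by hydrogen in place of fluoro on an aromatic carbon, which is the same change that turns compound 1 into compound 3: the change happens at the same kind of place in both pairs. Because the earlier step was a 1.6-fold lower number from compound 1 to compound 3 (0.20 log units; within the scatter), a step of about that size is expected from compound 2 to compound 4, namely a 1.3-fold lower number from compound 2 to compound 4 (0.13 log units; within the scatter). On that basis compound 4 is estimated to give 100 nM in this assay, most likely between 40 nM and 300 nM.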

Compound 4, half-maximal inhibitory concentration: "not active" (no number reported)
Compound 4 has no reported number here, and the estimate cannot be compared.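

In this assay, among these compounds, compound 4 is reported only as not active, with no number, so no step from compound 2 to compound 4 can be read. The compounds shown leave open how far hydrogen in place of fluoro shifts the number when the trimethoxy-bearing compounds are compared. Nothing given here explains this result.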